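The compounds below may be only part of what the source reports. "The series", "measured", "known", "first", "only" and "open" are said of these compounds alone.

Among the compounds with values here, compound 1 `COc1cc(-c2nc3ccccc3s2)ccc1OCC(=O)NNC(=O)CN[C@@H](CS)C(=O)O` gives 3120 nM in a functional assay on HepG2 cells (Homo sapiens) for inhibition, read by MTT assay, with a stated time of 3 days; on this read-out higher numbers stand for weaker inhibition and lower numbers for stronger inhibition; this is the second highest of the three numbers so far, sitting between compound 2 `COc1cc(-c2nc3ccccc3s2)ccc1OCC(=O)NNC(=O)CN1CCC[C@H]1C(=O)O` at 2650 nM and compound 3 `CCOC(=O)[C@H](CS)NCC(=O)NNC(=O)COc1ccc(-c2nc3ccccc3s2)cc1OC` at 3760 nM. All three measured steps stay within the scatter: a 1.2-fold lower number from compound 1 to compound 2 (0.07 log units; within the scatter), a 1.2-fold higher number from compound 1 to compound 3 (0.08 log units; within the scatter) and a 1.4-fold higher number from compound 2 to compound 3 (0.15 log units; within the scatter). Compound 4 `CCOC(=O)[C@H](CS(=O)(=O)O)NCC(=O)NNC(=O)COc1ccc(-c2nc3ccccc3s2)cc1OC` differs from compound 1 by 1-(ethoxycarbonyl)-2-sulfoethyl in place of 1-carboxy-2-sulfanylethyl on an amine nitrogen. Within the data shown here, the ethyl ester part of this change is already covered by a 1.2-fold higher number from compound 1 to compound 3 (0.08 log units; within the scatter), which was flat; the sulfo part has no counterpart among the measured steps. No step beyond the scatter is therefore expected in this assay. Compound 4 is estimated to give 3600 nM (range 1800 nM to 7500 nM), an expected step of a 1.2-fold higher number from compound 1 to compound 4 (0.06 log units; within the scatter).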

Compound 4, half-maximal inhibitory concentration: 3360 nM
The estimate for compound 4 lay 1.1-fold (0.03 log units) above the measured number, within the range that was stated.
By their numbers in this assay, from the lowest: compounds 2, 1, 4 and 3 (each within the scatter of the next).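

In this assay, sulfo in place of sulfanyl on the saturated chain carbon leaves the number flat, with a 1.1-fold lower number from compound 3 to compound 4 (0.05 log units; within the scatter) within the scatter. The full change on the amine nitrogen gives a 1.1-fold higher number from compound 1 to compound 4 (0.03 log units; within the scatter), and the exchange for 2-carboxypyrrolidin-1-yl gives a 1.3-fold higher number from compound 2 to compound 4 (0.10 log units; within the scatter), so none of the four side chains shown stands apart. No data on hand account for this flatness. Still open, on these data alone, is whether an amine in place of the sulfo group, or a longer chain on the amine nitrogen, would give a step beyond the scatter. Also open, as far as these compounds go, is how a free carboxylic acid behaves together with the sulfo group.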